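The source may hold more compounds than are shown below. What is called first, only, known or untested is meant among the compounds shown, and "the series" means these compounds.

The whole study is read in an ADME assay on MDCK cells (Canis lupus familiaris) for cytotoxicity, read by CellTiter-Glo, with a stated time of 40 h; on this read-out higher numbers stand for lower toxicity in this test and lower numbers for higher toxicity in this test. Compound 1, `C=CC(C)(C)c1[nH]c2c(C[C@H](O)C(C)(C)OC)cccc2c1/C=C1\NC(=O)[C@H](C)NC1=O`, gives in this assay only a limit of the test, > 200000 nM. Compound 2, `C=CC(C)(C)c1[nH]c2ccccc2c1/C=C1\NC(=O)[C@@](CO)(OC)NC1=O`, likewise gives only a limit of the test in this assay, > 200000 nM. Where compound 2 stands is therefore known only as a limit; both values shown sit at the same limit, (the limit of > 200000 nM in this assay, at which 2 of the 2 values shown sit), so no number sets compound 2 apart from compound 1 in this assay.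

Compound 3, `C=CC(C)(C)c1[nH]c2ccccc2c1/C=C1\NC(=O)[C@@](C)(OC)NC1=O`, is not yet measured in this assay. It differs from compound 2 in one place: hydrogen in place of hydroxy on a saturated chain carbon bound to a saturated ring carbon. No step between measured compounds is shown, so the effect of this change cannot be read from a measured pair. Because compound 2 reports only the limit > 200000 nM in this assay, the step from compound 2 to compound 3 is expected to be a number no higher from compound 2 to compound 3 (the limit leaves the size open), none beyond the scatter. Compound 3 is accordingly expected to give 200000 nM, within a range from 100000 nM to 400000 nM, most likely again reported as a limit in this assay.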

Compound 3, half-maximal cytotoxic concentration: > 200000 nM
Compound 3: only a limit was reported; the forecaster's own chance of this, stated with the estimate: 85%; the middle value lies on the limit itself.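

Compound 3, like compound 2, is reported in this assay only as a limit, so no step can be read between compound 2 and compound 3, and all the compounds shown sit at the same point: the limit of > 200000 nM in this assay, at which 3 of the 3 values shown sit.

The compounds shown leave open how far each lies from that limit, and whether hydroxymethyl or methyl makes any difference in this assay.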